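The source may report more compounds than this note shows. Statements on the series, on what has been measured and on what is new or still open speak of the compounds shown alone.

Compound 2 `O=C(/C(=C/c1ccc(Cl)cc1Cl)CCl)c1ccccc1` is the anchor for this step. Among the measured compounds shown here, in a functional assay on SW1573 cells (Homo sapiens) for inhibition, read by sulforhodamine B assay, with a stated time of 48 h (a higher number here means a weaker inhibitor of growth, a lower number a stronger inhibitor of growth), compound 2 gives 3800 nM, the lowest of the two numbers in hand, though its only neighbour, compound 1 `O=C(/C(=C/c1ccc(Cl)cc1)CCl)c1ccccc1`, gives 3900 nM in this assay, and the step of a 1.0-fold lower number from compound 1 to compound 2 (0.01 log units; within the scatter) is within the scatter, so no order between the two can be claimed.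

Compound 3 `CC(=O)OC/C(=C\c1ccc(Cl)cc1Cl)C(=O)c1ccccc1` differs from compound 2 by acetoxy in place of chloro on a saturated chain carbon bound to a double-bonded chain carbon. For the measured compounds named here, the one measured step concerns chloro on an aromatic carbon and does not touch the saturated chain carbon, so no measured step bears on the present change. What chloromethyl to acetoxymethyl does in this assay is simply unknown from these two compounds.

The expectation for compound 3 therefore rests on compound 2 alone, at 3800 nM, with a wide band around it; the estimated step of a 1.6-fold higher number from compound 2 to compound 3 (0.20 log units; within the scatter) is a placeholder rather than a trend. Compound 3 is estimated at 6000 nM, expected between 2000 nM and 20000 nM.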

Compound 3, concentration for 50% growth inhibition: 3500 nM
Estimate against measurement, compound 3: 1.7-fold (0.23 log units) above, and the stated range covers the measured number.
By their numbers in this assay, from the lowest: compounds 3, 2 and 1 (each within the scatter of the next).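

Acetoxy in place of chloro on a saturated chain carbon bound to a double-bonded chain carbon is the first measured change at this position, and the step is a 1.1-fold lower number from compound 2 to compound 3 (0.04 log units; within the scatter) in this assay for this pair. The chloro on this carbon is therefore not required for compound 3 to inhibit growth in the same range as compound 2, and a group of four heavy atoms with two hydrogen-bond acceptors is accepted here in this one pair. Nothing in hand accounts for why chloromethyl and acetoxymethyl read alike.

As far as these compounds go, whether an amine, a hydroxyl or a longer ester chain on this carbon would also stay in this range remains open. Also open, from the compounds shown here alone, is whether acetoxymethyl reads the same on the core of compound 1, which carries one chloro on the aromatic ring.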